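The compounds below may be only part of what the source reports. "The series", "measured", "known", "first", "only" and "open" are said of these compounds alone.

Compound 1 `CCOC(=O)c1cc(-c2cccc(OCc3cccc(F)c3)c2)on1` gives > 128000 nM in an ADME assay on Vero cells (Chlorocebus sabaeus) for cytotoxicity, with a stated time of 72 h (on this read-out higher numbers stand for weaker inhibition and lower numbers for stronger inhibition), a limit of the assay and not a number.
Compound 2 `CCOC(=O)c1cc(-c2cccc(OCc3cccc(OC(F)(F)F)c3)c2)on1` gives 101000 nM in this assay.
Compound 3 `CCOC(=O)c1cc(-c2cccc(OCc3cccc(OC)c3)c2)on1` gives > 128000 nM in this assay, again a limit and not a number.

Compound 3 thus sits at the limit of > 128000 nM in this assay, at which 2 of the 3 values shown sit, and has no number of its own. Compound 4 `CCOC(=O)c1cc(-c2cccc(OCc3cccc(C)c3)c2)on1` differs from it by methyl in place of methoxy on an aromatic carbon. Of the measured steps, an at least 1.2-fold higher number from compound 2 to compound 3 (0.10 log units; that floor lies within the scatter) and an at least 1.2-fold lower number from compound 1 to compound 2 (0.10 log units; that floor lies within the scatter) both stay within the scatter, and a step that the two limits leave unreadable from compound 1 to compound 3 cannot be read; none of the three moved the read-out beyond the scatter. For compound 4 in this assay no step beyond the scatter is therefore expected, a number no higher from compound 3 to compound 4 (the limit leaves the size open). Compound 4 is estimated at 128000 nM, with a range of 64000 nM to 256000 nM, and will most likely again be reported only as a limit.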

Compound 4, half-maximal inhibitory concentration: > 128000 nM
Compound 4: no number, only a limit; the forecaster's own chance of this, stated with the estimate: 70%; the middle value sits exactly at the limit.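

Compound 4 shows that methyl, a group joined through carbon, also leaves this place on the ring at a limit and not a number in this assay: the limit of > 128000 nM in this assay, at which 3 of the 4 values shown sit.

Against the one real number in the set, trifluoromethoxy to methyl gives an at least 1.2-fold higher number from compound 2 to compound 4 (0.10 log units; that floor lies within the scatter). The steps from compound 1 and from compound 3 to compound 4 cannot be read.

Any differences among compound 1, compound 3 and compound 4 remain hidden by the limit. From the compounds shown here alone, how an amine, a carboxylic acid or a longer chain at this place would read stays open.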